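The compounds below may be only part of what the source reports. "The series", "measured", "known", "first", "only" and "open" are said of these compounds alone.

Working notes on the series, read in a functional assay for inhibition, with Homo sapiens as the target; a lower number here means that less compound is needed, a higher number that more compound is needed for the effect. Compound 1 `Nc1ccc(C2=NNC(=O)CC2)cc1` gives 46.4 ug/mL, compound 2 `CC(Cl)C(=O)Nc1ccc(C2=NNC(=O)CC2)cc1` gives 0.45 ug/mL, and compound 3 `O=C1CCC(c2ccc(NC(=O)CCCl)cc2)=NN1` gives 0.98 ug/mL. Compound 3 therefore holds the second highest of the three numbers, close to compound 2 and far from compound 1.

Compound 4 `CCC(Cl)C(=O)Nc1ccc(C2=NNC(=O)CC2)cc1` differs from compound 3 by a group of 4 heavy atoms (3 carbon, 1 chlorine; no ring) in place of a group of 3 heavy atoms (2 carbon, 1 chlorine; no ring), on a carbonyl carbon. Two measured steps set the scale for the acyl groups as a whole, and both are large: a 100-fold lower number from compound 1 to compound 2 (2.01 log units; beyond the scatter) and a 47-fold lower number from compound 1 to compound 3 (1.68 log units; beyond the scatter). They compare an acyl group with the hydrogen and say little about a change from one such group to another. The step that bears most directly is the modest 2.2-fold higher number from compound 2 to compound 3 (0.34 log units; beyond the scatter), since the group entering in compound 4 resembles the 1-chloroethyl of compound 2 more than the 2-chloroethyl of compound 3. Among the measured compounds shown here, no measured step tests a longer group on this carbonyl carbon, so that part of the change remains open.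

In this assay, a slight lean toward a lower number is expected, with no clear move beyond the scatter. The expected change is a 1.6-fold lower number from compound 3 to compound 4 (0.21 log units; within the scatter). For compound 4 the estimate is 0.6 ug/mL, with an expected range of 0.2 ug/mL to 1.8 ug/mL.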

Compound 4, half-maximal effective concentration: 1.47 ug/mL
Estimate against measurement, compound 4: 2.5-fold (0.39 log units) below, within the range that was stated.
By their numbers in this assay, from the lowest: compound 2; then compounds 3 and 4 (each within the scatter of the next); then compound 1.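

In this assay, among the compounds shown here, the first change of one chlorinated acyl group for another that does not involve moving the chlorine stays small: a 1.5-fold higher number from compound 3 to compound 4 (0.18 log units; within the scatter) is the reading for the group of 4 heavy atoms in place of 2-chloroethyl on this carbonyl carbon. The sharper reading comes from methyl in place of hydrogen on the saturated chain carbon, where a 3.3-fold higher number from compound 2 to compound 4 (0.51 log units; beyond the scatter) shows that the added carbon is not neutral against the 1-chloroethyl of compound 2, although the step is modest. The large gain over the free amine survives this change, with a 32-fold lower number from compound 1 to compound 4 (1.50 log units; beyond the scatter) as the measure, so the longer group still sits among the acylated compounds and far from compound 1.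

Going by these compounds, whether a longer chain on this carbonyl carbon continues the rise seen from compound 2 to compound 4 remains open, as does the effect of branching with an isopropyl group at the same chain carbon. How much of the gain over compound 1 depends on the chlorine also remains open, since a plain propanoyl or butanoyl group would be needed to separate the acyl group from the halogen, and nothing at hand gives a measured reason for any of these steps.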